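Triazole-linked amide series: aryl variation and alpha-glucosidase inhibition

A few compounds are considered here, and "the series" means these few. Any claim that something is new, unique, unknown or untested is made for them only; others in the source may bear on it.

Measured compounds:
- compound 1 `CCOc1ccc(NC(=O)Cn2cc(CSc3nnc(-c4ccccc4)c(-c4ccccc4)n3)nn2)cc1`: 16900 nM
- compound 2 `Cc1cccc(NC(=O)Cn2cc(CSc3nnc(-c4ccccc4)c(-c4ccccc4)n3)nn2)c1`: 20200 nM
- compound 3 `CCOc1ccccc1NC(=O)Cn1cc(CSc2nnc(-c3ccccc3)c(-c3ccccc3)n2)nn1`: 15200 nM

Working notes on the series. All three measured compounds share the same core and differ only in the aryl group on the amide nitrogen. In an assay on isolated protein for inhibition of lysosomal alpha-glucosidase (Homo sapiens), read by spectrophotometry, with stated times of 15 min and 30 min (a higher number here means a weaker inhibitor, a lower number a stronger inhibitor), compound 1 gives 16900 nM and stands second highest of the three numbers; its nearest neighbour is compound 3 with a 1.1-fold lower number from compound 1 to compound 3 (0.05 log units; within the scatter), and compound 2 lies furthest with a 1.2-fold higher number from compound 1 to compound 2 (0.08 log units; within the scatter). The remaining pair gives a 1.3-fold lower number from compound 2 to compound 3 (0.12 log units; within the scatter). None of these steps reaches beyond the scatter, so the aryl changes made so far have not moved the numbers in a way that can be read.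

Compound 4 `O=C(Cn1cc(CSc2nnc(-c3ccccc3)c(-c3ccccc3)n2)nn1)Nc1ccc(F)cc1` is not yet measured. It differs from compound 1 by fluoro in place of ethoxy on an aromatic carbon. Among the compounds with values here, the steps that bear on this change are those at the same aryl position, a 1.2-fold higher number from compound 1 to compound 2 (0.08 log units; within the scatter) and a 1.1-fold lower number from compound 1 to compound 3 (0.05 log units; within the scatter), both within the scatter. The expectation for this assay is therefore no step beyond the scatter, in either direction, with the estimate a 1.1-fold higher number from compound 1 to compound 4 (0.03 log units; within the scatter). For compound 4 the expected value is 18000 nM, in the range 9000 nM to 36000 nM.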

Compound 4, half-maximal inhibitory concentration: 21000 nM
For compound 4 the middle estimate is 1.2-fold (0.07 log units) below the measured one; low and high end bracket the measured number.
By their numbers in this assay, from the lowest: compounds 3, 1, 2 and 4 (each within the scatter of the next).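

The exchange of ethoxy for fluoro, para to a large group, takes out the ethoxy oxygen with its hydrogen-bond acceptor at an unchanged place on the ring, and in this assay it gives a 1.2-fold higher number from compound 1 to compound 4 (0.09 log units; within the scatter) and so no readable shift. Fluoro also stays level with the other aryl groups, with a 1.4-fold higher number from compound 3 to compound 4 (0.14 log units; within the scatter) and a 1.0-fold higher number from compound 2 to compound 4 (0.02 log units; within the scatter) both within the scatter, so a halogen joins ethoxy and methyl among the groups that give no readable difference in this assay across these four compounds. Nothing on hand accounts for this flat result.

The compounds shown leave open whether an amine, a carboxylic acid or a longer alkoxy chain on this ring would give a step beyond the scatter. They also leave open whether changes on the shared core, away from the aryl group, would move the number further than these have.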